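Ring-opened diamine chain in place of the pyrrolidine

The compounds below may be only part of what the source reports. "The series", "measured", "known", "first", "only" and "open" are said of these compounds alone.

Compound 2 `COc1c(N2CC[C@@H](CN)C2)c(F)cc2c(=O)c(C(=O)O)cn(Cc3ccc(-c4ccccc4)cc3)c12` gives 26000 nM in an assay on isolated protein for inhibition of DNA topoisomerase 1 (Homo sapiens), with a stated time of 15 min (on this read-out lower numbers stand for stronger inhibition and higher numbers for weaker inhibition), the lowest of the two numbers shown. Compound 3 `COc1c(N2CC[C@@H](CN)C2)c(F)cc2c(=O)c(C(=O)NO)cn(Cc3ccc(-c4ccccc4)cc3)c12` gives 35900 nM, so a 1.4-fold higher number from compound 2 to compound 3 (0.14 log units; within the scatter). Compound 1 `COc1c(N2CC[C@@H](CO)C2)c(F)cc2c(=O)c(C(=O)O)cn(Cc3ccc(-c4ccccc4)cc3)c12` sits at a limit of this assay, (the limit of > 200000 nM in this assay, at which 1 of the 3 values shown sits), not a number; in this assay compound 1 gives > 200000 nM. Compound 4 `CNCCCNc1c(F)cc2c(=O)c(C(=O)O)cn(Cc3ccc(-c4ccccc4)cc3)c2c1OC` carries (3-(methylamino)propyl)amino in place of 3-(aminomethyl)pyrrolidin-1-yl on an aromatic carbon. For the measured compounds named here, the only step at this position, an at least 7.6-fold lower number from compound 1 to compound 2 (0.88 log units; beyond the scatter), shows that the basic amine on the side chain matters; compound 4 keeps a secondary amine on its chain. Going by the values given here, no measured pair swaps a ring for an open chain, so a step within the scatter or a modest weakening is expected, a 1.5-fold higher number from compound 2 to compound 4 (0.19 log units; within the scatter). Compound 4 is estimated at 40000 nM, range 12000 nM to 150000 nM.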

Compound 4, half-maximal inhibitory concentration: 101000 nM
Estimate against measurement, compound 4: 2.5-fold (0.40 log units) below, and the stated range covers the measured number.
By their numbers in this assay, from the lowest: compounds 2 and 3 (each within the scatter of the next); then compound 4. At a limit, above all of these: compound 1.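

Exchanging the 3-(aminomethyl)pyrrolidin-1-yl group for the open (3-(methylamino)propyl)amino chain gives a 3.9-fold higher number from compound 2 to compound 4 (0.59 log units; beyond the scatter), so at this aromatic carbon, a second nitrogen on the group does not alone keep the number of compound 2. The step of an at least 1.9-fold lower number from compound 1 to compound 4 (0.29 log units; that floor lies within the scatter) gives only a floor, and the limit belongs to compound 1: the limit of > 200000 nM in this assay, at which 1 of the 4 values shown sits.

The effect of opening the ring remains unseparated from that of the terminal methylamino group. A terminal primary amine on the same propyl chain, or a piperazine ring at this carbon, would bear on that question.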